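The source may report more compounds than this note shows. Statements on the series, on what has been measured and on what is new or still open speak of the compounds shown alone.

Among the compounds with values here, compound 1 `Cc1ccc(-c2nn(-c3ccccc3)cc2C(=O)NC(=S)Nc2ccc(Cl)cc2)cc1` gives 3170 nM in a functional assay on A549 cells (Homo sapiens) for inhibition, read by CCK-8 assay, with a stated time of 48 h (on this read-out lower numbers stand for stronger inhibition and higher numbers for weaker inhibition), the second highest of the three numbers measured so far. Compound 3 `O=C(NC(=S)Nc1ccc(F)cc1)c1cn(-c2ccccc2)nc1-c1ccc(F)cc1` gives 3540 nM and compound 2 `Cc1ccc(NC(=S)NC(=O)c2cn(-c3ccccc3)nc2-c2ccc(C)cc2)cc1` gives 2830 nM; both sit within the scatter of compound 1. Within the data shown here, the single measured step, a 1.1-fold lower number from compound 1 to compound 2 (0.05 log units; within the scatter), concerns a different ring of the shared core and stays within the scatter. Compound 4 `O=C(NC(=S)Nc1ccc(Cl)cc1)c1cn(-c2ccccc2)nc1-c1ccccc1` differs from compound 1 by hydrogen in place of methyl on an aromatic carbon. Among the measured compounds shown here, no measured step removes this methyl; compound 3 changes two places at once, so its number cannot be read as a step for it. With all three measured numbers close together, no step beyond the scatter is expected. Compound 4 is therefore expected near 3300 nM, in a range of 1500 nM to 7000 nM. The estimated step is a 1.0-fold higher number from compound 1 to compound 4 (0.02 log units; within the scatter).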

Compound 4, half-maximal inhibitory concentration: 3200 nM
Estimate against measurement, compound 4: 1.0-fold (0.01 log units) above; the range from low to high includes it.
By their numbers in this assay, from the lowest: compounds 2, 1, 4 and 3 (each within the scatter of the next).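

In this assay, within the data shown here, the change from 4-methylphenyl to phenyl gives a 1.0-fold higher number from compound 1 to compound 4 (0.00 log units; within the scatter) and is the first measured step at this position. On this six-membered aromatic ring, para to a large group, hydrogen can thus replace methyl without a readable change when the chloro on the other ring stays fixed. No measured evidence bears on this result.

As far as these compounds go, whether a carboxylic acid or an amine on the same aromatic carbon would also stay within the scatter remains open. Also open, from the compounds shown here alone, is whether this step holds with fluoro in place of the chloro.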